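Replacing a urea link with an amide in a pyrazole series

A few compounds are considered here, and "the series" means these few. Any claim that something is new, unique, unknown or untested is made for them only; others in the source may bear on it.

Three compounds sharing one core were measured in a functional assay on HOP-62 cells (Homo sapiens) for inhibition, read by sulforhodamine B assay, with a stated time of 48 h, tested at 0.1 uM; a higher number here means a weaker effect of the compound at the concentration tested, a lower number a stronger effect. Compound 1 `O=C(Nc1cccc(-n2cc(-c3ccncc3)c(-c3cc(O)cc(Cl)c3)n2)c1)Nc1ccc(Cl)c(C(F)(F)F)c1` gives 97%. Compound 2 `COc1cc(Cl)cc(-c2nn(-c3cccc(NC(=O)Nc4ccc(Cl)c(C(F)(F)F)c4)c3)cc2-c2ccncc2)c1` gives 104%, and compound 3 `COc1cc(Cl)cc(-c2nn(-c3cccc(NC(=O)Nc4cc(C(F)(F)F)cc(C(F)(F)F)c4)c3)cc2-c2ccncc2)c1` gives 93%. Compound 2 sits close to compound 1, whose number is within the scatter of it, while compound 3 lies beyond the scatter below compound 2. Going by the values given here, the single measured step, a number 7 percentage points higher from compound 1 to compound 2 (within the scatter), concerns a methyl in place of hydrogen on an oxygen on an aromatic ring and does not touch the part of the molecule that changes next.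

Compound 4 `COc1cc(Cl)cc(-c2nn(-c3cccc(NC(=O)c4cccc(C(F)(F)F)c4)c3)cc2-c2ccncc2)c1` differs from compound 2 in one place: 3-(trifluoromethyl)phenyl in place of (4-chloro-3-(trifluoromethyl)phenyl)amino on a carbonyl carbon. Among the compounds with values here, no measured step bears on this change, so the expectation rests only on the narrow spread of the three numbers, all of which show little effect at the concentration tested. A step of a number 6 percentage points lower from compound 2 to compound 4 (within the scatter) is expected, that is, none beyond the scatter. Compound 4 is therefore estimated to give 98% in this assay, within a range from 85% to 110%.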

Compound 4, a percentage reported as activity, at one concentration (the size of the read-out at that concentration, not a potency): 101%
For compound 4 the middle estimate is 3 percentage points below the measured one, and the stated range covers the measured number.
By their numbers in this assay, from the lowest: compounds 3, 1, 4 and 2 (each within the scatter of the next, the first and the last beyond it).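

In this assay, going by these compounds alone, putting 3-(trifluoromethyl)phenyl in place of (4-chloro-3-(trifluoromethyl)phenyl)amino on the carbonyl carbon gives a number 3 percentage points lower from compound 2 to compound 4 (within the scatter), the first reading at this position. The urea link can thus give way to an amide, losing the hydrogen-bond donor of the group that leaves along with its chlorine, without the number moving beyond the scatter, although this single step cannot separate those two parts of the change. No measurement given here offers an explanation for this result.

Since compound 2 and compound 4 both show little effect at the concentration tested, this step says little about the position in a compound with a clear effect. From the compounds shown here alone, whether a piperidine or a butyl chain on this carbonyl carbon would shift the number beyond the scatter remains open.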